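A few compounds are considered here, and "the series" means these few. Any claim that something is new, unique, unknown or untested is made for them only; others in the source may bear on it.

Of the compounds shown here, three sharing one core have been tested in an assay on CHO cells for displacement of a labelled ligand from adenosine receptor A3 (Homo sapiens), read by scintillation counting, with a stated time of 60 min; on this read-out higher numbers stand for weaker inhibition and lower numbers for stronger inhibition. Compound 1, `O=C(C/C=C/c1cccc(Cl)c1)Nc1nc2ccccc2c(=O)s1`, reaches only a limit of the assay, giving > 1000 nM in this assay; this is a limit rather than a number, and (the limit of > 1000 nM in this assay, at which 1 of the 3 values shown sits). Compound 2, `O=C(CCc1ccccc1)Nc1nc2ccccc2c(=O)s1`, gives 390 nM in this assay, which is the highest of the two numbers shown. Compound 3, `Cc1ccc2nc(NC(=O)CCCc3ccccc3)sc(=O)c2c1`, gives 147 nM in this assay, a number lower than that of compound 2 by more than the usual scatter. No two of these compounds differ in a single place, so no measured step can be read from them.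

Compound 4, `O=C(CCc1ccc(Cl)c(Cl)c1)Nc1nc2ccccc2c(=O)s1`, has not yet been measured. It differs from compound 2 in one place: 3,4-dichlorophenyl in place of phenyl on a saturated chain carbon, two bonds along the chain from a carbonyl carbon. The chain and the core stay as they are in compound 2, and only the aromatic ring at the end of the chain is altered.

Since no measured step of this kind exists among the compounds shown, the direction of the change is uncertain. The step of a 1.6-fold lower number from compound 2 to compound 4 (0.19 log units; within the scatter) is expected to be modest and toward stronger inhibition, though it may well fall within the scatter. Compound 4 is therefore estimated at 250 nM, within a range from 80 nM to 800 nM.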

Compound 4, inhibition constant: > 1000 nM
Compound 4: a limit, no number (the forecaster's own chance of this, stated with the estimate: 10%); middle value at least 4.0-fold (0.60 log units) from the limit.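

For the compounds shown here, the change to 3,4-dichlorophenyl in place of phenyl, on a saturated chain carbon two bonds along the chain from a carbonyl carbon, gives the first measured step in this set: an at least 2.5-fold higher number from compound 2 to compound 4 (0.40 log units; beyond the scatter). The chain and the core stay the same, so the ring at the end of the chain is shown to matter in this assay, and this change moves the compound toward weaker inhibition by more than the usual scatter. Compound 4 gives > 1000 nM, which is a limit of the assay and not a number, so the step has a minimum size but no known true size, and the limit is now a common result in this small set: the limit of > 1000 nM in this assay, at which 2 of the 4 values shown sit.

This single step cannot show whether the loss comes from either chlorine alone or from having both, so a ring with one chlorine, one fluorine or one methoxy group would be needed to separate these cases. Going by these compounds, it is also open whether the same two chlorines would have a similar effect on a longer chain, or whether an amine on the ring would be tolerated.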